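This account rests on a few compounds, and the source may have more. Where it says the series, first, only, none or still open, it means among the compounds named here.

Measured so far in an assay for inhibition of serine/threonine-protein kinase PAK 4 (Homo sapiens), read by FRET and Z'-LYTE, with a stated time of 60 min, tested at 0.5 uM, in the presence of a further agent that is not named here; a higher number here means a stronger effect of the compound at the concentration tested, a lower number a weaker effect:
- compound 1 `CCOC(=O)N1CCN(C(=O)c2nc(Nc3cc(C4CC4)[nH]n3)c3cc(Cl)ccc3n2)C[C@H]1C` — 42.4%
- compound 2 `CCCCCOC(=O)N1CCN(C(=O)c2nc(Nc3cc(C4CC4)[nH]n3)c3cc(Cl)ccc3n2)C[C@H]1C` — -3.8%
- compound 3 `C[C@@H]1CN(C(=O)c2nc(Nc3cc(C4CC4)[nH]n3)c3cc(Cl)ccc3n2)CCN1C(=O)OCOC(=O)C(C)(C)C` — 0.7%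

Compound 3 stands second highest of the three numbers, within the scatter of compound 2 and well beyond the scatter below compound 1. Compound 4 `COC(=O)N1CCN(C(=O)c2nc(Nc3cc(C4CC4)[nH]n3)c3cc(Cl)ccc3n2)C[C@H]1C` has not yet been measured. The change from compound 3 to compound 4 is hydrogen in place of ((tert-butyl)carbonyl)oxy on a saturated chain carbon bound to an oxygen next to a carbonyl group.

Among the measured compounds shown here, two measured steps bear on it. From compound 1 the ((tert-butyl)carbonyl)oxy group was introduced at this very position, giving a number 41.7 percentage points lower from compound 1 to compound 3 (beyond the scatter); the step from compound 3 to compound 4 removes that group again, leaving a still shorter chain on the carbamate oxygen. The other enlargement on the same chain gave a number 46.2 percentage points lower from compound 1 to compound 2 (beyond the scatter), and the two enlarged compounds sit together, as a number 4.5 percentage points higher from compound 2 to compound 3 (within the scatter) shows. Both enlargements cost heavily; the reverse move is therefore expected to recover activity by a large margin, toward the level of compound 1, with the estimated step being a number 39.3 percentage points higher from compound 3 to compound 4 (beyond the scatter). For compound 4 the estimate is 40%, with a range from 18% to 62%.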

Compound 4, a percentage reported as inhibition, at one concentration (the size of the read-out at that concentration, not a potency): 73.9%
Beside the measured number, compound 4's estimate is 33.9 percentage points below it, outside the stated range (above it).
By their numbers in this assay, from the lowest: compounds 2 and 3 (each within the scatter of the next); then compound 1; then compound 4.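

In this assay, hydrogen in place of ((tert-butyl)carbonyl)oxy gives a number 73.2 percentage points higher from compound 3 to compound 4 (beyond the scatter), and hydrogen in place of butyl gives a number 77.7 percentage points higher from compound 2 to compound 4 (beyond the scatter), so the methoxycarbonyl compound does more than return to the level of the ethyl carbamate. Hydrogen in place of methyl on the same carbon gives a number 31.5 percentage points higher from compound 1 to compound 4 (beyond the scatter), which shows that even this single methyl matters at this position, whereas the earlier compounds showed only a loss with the two larger groups; compound 2 and compound 3 do not separate from each other within this order. Nothing measured here explains these steps.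

From the compounds shown here alone, it remains open whether a urea or an amide in place of the carbamate would hold this level at the same position. A read-out at a single concentration also leaves the potency of compound 4 undefined.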